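Methoxy in Place of Bromo on the Shared Core

The source may hold more compounds than are shown below. What is called first, only, known or untested is meant among the compounds shown, and "the series" means these compounds.

In a functional assay on PC-3 cells (Homo sapiens) for cytotoxicity, read by colorimetric assay (a lower number here means a stronger inhibitor, a higher number a weaker inhibitor), compound 2 `O=C(NO)c1ccc(CN2C(=O)/C(=C3\Nc4ccccc4\C3=N/O)c3cc(Br)ccc32)cc1` gives 50 nM and compound 1 `Cc1ccc2c(c1)/C(=C1/Nc3ccccc3/C1=N\O)C(=O)N2Cc1ccc(C(=O)NO)cc1` gives 90 nM so the two stand within the scatter of each other. Compound 3 `COc1ccc2c(c1)/C(=C1/Nc3ccccc3/C1=N\O)C(=O)N2Cc1ccc(C(=O)NO)cc1` carries methoxy in place of bromo on an aromatic carbon. Among the compounds with values here, the one measured step at this place is a 1.8-fold lower number from compound 1 to compound 2 (0.26 log units; within the scatter) and it stays within the scatter. Within the data shown here, no measured compound carries methoxy, so in this assay no step beyond the scatter is expected. The estimated change is a 1.6-fold higher number from compound 2 to compound 3 (0.20 log units; within the scatter) and no direction is firmly expected. Compound 3 is expected at 80 nM (estimated range 35 nM to 180 nM).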

Compound 3, half-maximal inhibitory concentration: 30 nM
Beside the measured number, compound 3's estimate is 2.7-fold (0.43 log units) above it; measured number below the stated range.
By their numbers in this assay, from the lowest: compounds 3, 2 and 1 (each within the scatter of the next, the first and the last beyond it).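

In this assay this position now shows a step beyond the scatter: methoxy in place of methyl gives a 3.0-fold lower number from compound 1 to compound 3 (0.48 log units; beyond the scatter) and so the group here does bear on the number, if only modestly. Methoxy in place of bromo gives a 1.7-fold lower number from compound 2 to compound 3 (0.22 log units; within the scatter) and so these two groups cannot be told apart. Nothing available explains either step.

Going by these compounds, what remains open is how an amine, a carboxylic acid or a longer chain such as ethoxy would read at this position. On these data alone, whether methoxy would give a similar step on another part of the shared core also stays open.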